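Moving the methoxy group of compound 2

This account rests on a few compounds, and the source may have more. Where it says the series, first, only, none or still open, it means among the compounds named here.

Compound 1 `O=C(CCCCCCNC(=O)C(O)(O)C(F)(F)F)Nc1ncc(-c2ccc(Br)cc2)s1`: 2460 nM
Compound 2 `COc1ccc(NC(=O)CCCCCCNC(=O)C(O)(O)C(F)(F)F)cc1`: 4520 nM

Both values come from a functional assay on HCT-116 cells (Homo sapiens) for inhibition, read by colorimetric assay, with a stated time of 3 days; on this read-out lower numbers stand for stronger inhibition and higher numbers for weaker inhibition. Compound 2 lies within the usual scatter of compound 1, so these two numbers cannot be told apart. Compound 3 `COc1ccccc1NC(=O)CCCCCCNC(=O)C(O)(O)C(F)(F)F` has the same atoms as compound 2, joined differently: 2-methoxyphenyl in place of 4-methoxyphenyl on an amide-type nitrogen. This places 2-methoxyphenyl in place of 4-methoxyphenyl on an amide-type nitrogen. Within the data shown here, no measured pair shows what such a change does, so in this assay no step beyond the scatter is expected. The estimated change is a 1.1-fold higher number from compound 2 to compound 3 (0.04 log units; within the scatter). Compound 3 is estimated at 5000 nM, with an expected range of 2000 nM to 12000 nM.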

Compound 3, half-maximal inhibitory concentration: 10100 nM
For compound 3 the middle estimate is 2.0-fold (0.31 log units) below the measured one; the range from low to high includes it.
By their numbers in this assay, from the lowest: compounds 1 and 2 (each within the scatter of the next); then compound 3.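

Where the methoxy group sits on the aromatic ring matters in this assay: with the same atoms, 2-methoxyphenyl in place of 4-methoxyphenyl on the amide-type nitrogen gives a 2.2-fold higher number from compound 2 to compound 3 (0.35 log units; beyond the scatter), a modest loss of inhibition. The earlier pair, compound 1 and compound 2, differs in more than one place and could not show this. Nothing measured here explains the loss. Still open, on these data alone, is whether an amine or a carboxylic acid in place of the methoxy group would keep the inhibition of compound 2, and whether a longer chain would alter this step.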